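The compounds below may be only part of what the source reports. "The series", "measured", "known", "first", "only" and "open" are said of these compounds alone.

Measured compounds:
compound 1 `CC(C)Oc1ccc(-c2cc(C(=O)O)nn2-c2ccc(Oc3ccccc3)cc2)cc1` — 932 nM
compound 2 `CC(C)Oc1ccc(-c2cc(C(=O)O)nn2-c2ccc(C(C)C)cc2)cc1` — 5250 nM
compound 3 `CC(C)Oc1ccc(C(=O)Nc2c(C(=O)O)nn(-c3ccc(Oc4ccccc4)cc3)c2-c2ccc(OCc3ccccc3)cc2)cc1` — > 10000 nM

In an assay for displacement of a labelled ligand from Apoptosis regulator Bcl-2 (Homo sapiens), read by fluorescence polarization, with a stated time of 30 min (a lower number here means a stronger inhibitor, a higher number a weaker inhibitor), compound 1 gives 932 nM. Compound 2 differs from it by one change, (isopropyl in place of phenoxy on an aromatic carbon), and in this assay compound 2 gives 5250 nM, so the step is a 5.6-fold higher number from compound 1 to compound 2 (0.75 log units; beyond the scatter). Compound 3 `CC(C)Oc1ccc(C(=O)Nc2c(C(=O)O)nn(-c3ccc(Oc4ccccc4)cc3)c2-c2ccc(OCc3ccccc3)cc2)cc1` carries a different core; how the core of compound 3 differs from that of compound 1 is not broken down here. For compound 3 this assay reports only a limit, > 10000 nM, and the limit of > 10000 nM in this assay, at which 1 of the 3 values shown sits, shows where that limit sits. Compound 4 `CC(C)Oc1ccc(C(=O)Nc2c(C(=O)O)nn(-c3ccc(C(C)C)cc3)c2-c2ccc(OCc3ccccc3)cc2)cc1` has not been measured in this assay. It differs from compound 3 by isopropyl in place of phenoxy on an aromatic carbon, the same change that separates compound 2 from compound 1. Since compound 3 already stands at a limit and the earlier step was a 5.6-fold higher number from compound 1 to compound 2 (0.75 log units; beyond the scatter), compound 4 is expected to give 30000 nM in this assay, most likely again reported as a limit, with a range of 10000 nM to 100000 nM. The step this estimate means is a step that the limit leaves unreadable from compound 3 to compound 4.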

Compound 4, inhibition constant: > 10000 nM
Compound 4 ended at the assay's limit; the forecaster's own chance of this, stated with the estimate: 90%; the middle value lies beyond the limit too.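

In this assay compound 4 gives > 10000 nM, a limit of the assay and not a number. Compound 3 likewise stands at a limit, > 10000 nM, so no step can be read between compound 3 and compound 4. As far as these compounds go, whether isopropyl in place of phenoxy shifts the number on the core of compound 3 as it does on the core of compound 1 stays open.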